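Chloro to Nitro: Expected Cytotoxicity of Compound 4

The source may report more compounds than this note shows. Statements on the series, on what has been measured and on what is new or still open speak of the compounds shown alone.

Measured compounds:
compound 1, `Nc1sc2c(c1-c1nc3ccccc3s1)CCCC2` — 475 ug/mL
compound 2, `Fc1ccccc1/C=N/c1sc2c(c1-c1nc3ccccc3s1)CCC2` — 355 ug/mL
compound 3, `Clc1ccc(/C=N/c2sc3c(c2-c2nc4ccccc4s2)CCCC3)cc1` — 431 ug/mL

Of the compounds shown here, three have been tested in an ADME assay on HeLa cells (Homo sapiens) for cytotoxicity, read by MTT assay, with a stated time of 72 h; on this read-out lower numbers stand for higher toxicity in this test and higher numbers for lower toxicity in this test. Compound 1 gives 475 ug/mL, compound 2 gives 355 ug/mL, and compound 3 gives 431 ug/mL. Among these three numbers compound 3 stands second highest; its nearest neighbour is compound 1 and its furthest is compound 2, and both gaps lie within the scatter, so no order among the three can be read from them. Going by the values given here, the only single-point step known, a 1.1-fold lower number from compound 1 to compound 3 (0.04 log units; within the scatter), is likewise within the scatter.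

Compound 4, `O=[N+]([O-])c1ccc(/C=N/c2sc3c(c2-c2nc4ccccc4s2)CCCC3)cc1`, differs from compound 3 in one place: nitro in place of chloro on an aromatic carbon. Among the compounds with values here, no measured step covers this exchange of one group for another on the six-membered ring. Within the data shown here, what bears on it is only the single known step, which is within the scatter, and the narrow spread of the three numbers. On that basis compound 4 is expected to show no step beyond the scatter in this assay, which the estimate expresses as a 1.0-fold lower number from compound 3 to compound 4 (0.01 log units; within the scatter). The estimate for compound 4 in this assay is 420 ug/mL, with a range from 250 ug/mL to 650 ug/mL.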

Compound 4, half-maximal cytotoxic concentration: 357 ug/mL
The estimate for compound 4 lay 1.2-fold (0.07 log units) above the measured number; the range from low to high includes it.
By their numbers in this assay, from the lowest: compounds 2, 4, 3 and 1 (each within the scatter of the next).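

In this assay, the exchange of 4-chlorophenyl for 4-nitrophenyl gives a 1.2-fold lower number from compound 3 to compound 4 (0.08 log units; within the scatter). This is the first change shown on the six-membered aromatic ring of carbon only, and it shows that at this place, para to a large group, a nitro group with three heavy atoms and two hydrogen-bond acceptors can stand where a single chlorine stood without a step beyond the scatter. The earlier step, a 1.1-fold lower number from compound 1 to compound 3 (0.04 log units; within the scatter), concerned the addition of the whole group on the aromatic carbon of the core, so it said nothing about an exchange on the ring itself, and no measurement at hand bears on why the number holds through this exchange.

The compounds shown leave open whether a step beyond the scatter can be reached at this place at all, for instance with an amine, a carboxylic acid or a longer chain in place of the nitro group. They also leave open whether the exchange of chloro for nitro would read the same with the group at another place on that ring.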